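The source may report more compounds than this note shows. Statements on the series, on what has been measured and on what is new or still open speak of the compounds shown alone.

Working notes on the series. Compound 1 `CC(C)=CC[C@@H](OC(=O)C1CCOC1)C1=CC(=O)c2c(O)ccc(O)c2C1=O` gives 73500 nM in a functional assay on HeLa cells (Homo sapiens) for cytotoxicity, read by MTT assay (on this read-out higher numbers stand for weaker inhibition and lower numbers for stronger inhibition), the highest of the three numbers measured. Compound 2 `CCCC(C)(O)CC(=O)O[C@H](CC=C(C)C)C1=CC(=O)c2c(O)ccc(O)c2C1=O` gives 72000 nM, with a 1.0-fold lower number from compound 1 to compound 2 (0.01 log units; within the scatter). Compound 3 `CC(C)=CC[C@@H](OCCO)C1=CC(=O)c2c(O)ccc(O)c2C1=O` gives 18600 nM, with a 4.0-fold lower number from compound 1 to compound 3 (0.60 log units; beyond the scatter) and a 3.9-fold lower number from compound 2 to compound 3 (0.59 log units; beyond the scatter). Compound 4 `CCC(CO[C@H](CC=C(C)C)C1=CC(=O)c2c(O)ccc(O)c2C1=O)OC` is not yet measured; it differs from compound 1 by 2-methoxybutyl in place of (oxolan-3-yl)carbonyl on an oxygen on a saturated carbon. Within the data shown here, the steps that bear on this are those to compound 3, where a carbonyl-bearing group on that oxygen is exchanged for a short chain and the number falls modestly, while the exchange of one acyl group for another between compound 1 and compound 2 stays within the scatter. A modest step downward is therefore expected, though compound 3 carries a hydroxyl where compound 4 carries a methoxy, so the size is uncertain. For compound 4 the expected value is 30000 nM, with a range of 12000 nM to 75000 nM, meaning an expected step of a 2.5-fold lower number from compound 1 to compound 4 (0.39 log units; beyond the scatter).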

Compound 4, half-maximal inhibitory concentration: 63500 nM
Beside the measured number, compound 4's estimate is 2.1-fold (0.33 log units) below it; the range from low to high includes it.
By their numbers in this assay, from the lowest: compound 3; then compounds 4, 2 and 1 (each within the scatter of the next).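

On an oxygen on a saturated carbon, removing the carbonyl does not by itself give the lower number of compound 3: 2-methoxybutyl in place of (oxolan-3-yl)carbonyl gives a 1.2-fold lower number from compound 1 to compound 4 (0.06 log units; within the scatter) in this assay and the exchange from the other acyl group gives a 1.1-fold lower number from compound 2 to compound 4 (0.05 log units; within the scatter) in the same read-out. The chain end matters instead, with 1-methoxypropyl in place of hydroxymethyl giving a 3.4-fold higher number from compound 3 to compound 4 (0.53 log units; beyond the scatter) on this read-out. No supporting data explain this step.

Going by these compounds, whether the free hydroxyl or the chain length drives it remains open, since both differ between compound 3 and compound 4. A 2-methoxyethyl or 2-aminoethyl group on that oxygen would help separate them.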